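Changing the Amide Partner to a Methyl Ester

A few compounds are considered here, and "the series" means these few. Any claim that something is new, unique, unknown or untested is made for them only; others in the source may bear on it.

Measured so far:
compound 1 `Nc1sc(-c2ccc(Cl)cc2)c(-c2ccc(Cl)cc2)c1C(=O)N1CCCC1`: 890 nM
compound 2 `Nc1sc(-c2ccc(Cl)cc2)c(-c2ccc(Cl)cc2)c1C(=O)NCc1ccccc1`: 16300 nM
compound 3 `Nc1sc(-c2ccc(Cl)cc2)c(-c2ccc(Cl)cc2)c1C(=O)N1CCCCC1=O`: 1820 nM

All three share one core and differ only in the group attached to the carbonyl carbon. In a functional assay on A549 cells (Homo sapiens) for inhibition, read by sulforhodamine B assay, with a stated time of 72 h (a higher number here means a weaker inhibitor, a lower number a stronger inhibitor), compound 1 gives 890 nM, the lowest of the three numbers. Compound 3 stands second highest: a 2.0-fold higher number from compound 1 to compound 3 (0.31 log units; beyond the scatter) separates it from compound 1, while compound 2 lies furthest away, with a 9.0-fold lower number from compound 2 to compound 3 (0.95 log units; beyond the scatter).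

Compound 4 `COC(=O)c1c(N)sc(-c2ccc(Cl)cc2)c1-c1ccc(Cl)cc1` has not yet been measured. Its change from compound 3 is methoxy in place of 2-oxopiperidin-1-yl on a carbonyl carbon. Among the measured compounds shown here, no measured step replaces an amide group with a methoxy group, so the nearest guidance is indirect: an 18-fold higher number from compound 1 to compound 2 (1.26 log units; beyond the scatter) and a 2.0-fold higher number from compound 1 to compound 3 (0.31 log units; beyond the scatter) both show that the group on the carbonyl carbon moves the number in this assay, sometimes by a large amount. Because of a 2.0-fold higher number from compound 1 to compound 3 (0.31 log units; beyond the scatter) a modest shift from compound 3 seems more likely than a large one, though the direction is uncertain.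

Compound 4 is therefore expected to give about 3000 nM, within a range of 800 nM to 12000 nM. That estimate corresponds to an expected 1.6-fold higher number from compound 3 to compound 4 (0.22 log units; within the scatter).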

Compound 4, half-maximal inhibitory concentration: 5040 nM
Estimate against measurement, compound 4: 1.7-fold (0.23 log units) below, within the range that was stated.
By their numbers in this assay, from the lowest: compound 1; then compound 3; then compound 4; then compound 2.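

In this assay, the carbonyl carbon does not need an amide nitrogen for the shared core to give a number in the low micromolar region, but methoxy gives a higher number than both pyrrolidin-1-yl (a 5.7-fold higher number from compound 1 to compound 4 (0.75 log units; beyond the scatter)) and 2-oxopiperidin-1-yl (a 2.8-fold higher number from compound 3 to compound 4 (0.44 log units; beyond the scatter)). Compound 2 goes against any simple rule that amides outperform the methyl ester, since methoxy gives a lower number than benzylamino (a 3.2-fold lower number from compound 2 to compound 4 (0.51 log units; beyond the scatter)). No measurement offered here explains this order.

The compounds shown leave open where a free carboxylic acid or an unsubstituted amide would fall in this order. They also leave open whether a longer ester chain, such as ethoxy, would move the number away from that of compound 4.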